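The compounds below may be only part of what the source reports. "The series", "measured", "known", "first", "only" and "open" are said of these compounds alone.

Among the measured compounds shown here, compound 1 `O=C(COc1cccc2ccccc12)N/N=C/c1ccc(Br)cc1` stands highest of the two numbers so far in a physicochemical assay for lipophilicity, measured as octanol-water partition (on this read-out lower numbers stand for lower lipophilicity and higher numbers for higher lipophilicity), where compound 1 gives 4.81. Compound 2 `O=C(COc1cccc2ccccc12)N/N=C/c1ccc([N+](=O)[O-])cc1` gives 3.97 in this assay, and a number 0.84 log units lower from compound 1 to compound 2 (beyond the scatter). Compound 3 `O=C(COc1cccc2ccccc12)N/N=C/c1cccc(Cl)c1` differs from compound 1 in one place: 3-chlorophenyl in place of 4-bromophenyl on a carbon with a double bond to nitrogen. For the measured compounds named here, the only measured step is a nitro-for-bromo exchange and does not match this change; no halogen-for-halogen step is in hand, so the expectation rests on the two values alone. The step expected for compound 3 is a number 0.21 log units lower from compound 1 to compound 3 (within the scatter), not beyond the scatter. The estimate for compound 3 in this assay is 4.6, between 4.3 and 4.9.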

Compound 3, partition coefficient: 4.54
The estimate for compound 3 lay 0.06 log units above the measured number; the measured number falls inside the stated range.
By their numbers in this assay, from the lowest: compound 2; then compounds 3 and 1 (each within the scatter of the next).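

In this assay, 3-chlorophenyl in place of 4-bromophenyl on a carbon with a double bond to nitrogen gives a number 0.27 log units lower from compound 1 to compound 3 (within the scatter), so this exchange does not separate the two compounds, whereas the nitro-for-bromo exchange gives a number 0.84 log units lower from compound 1 to compound 2 (beyond the scatter). The halogen and its place on the ring change together here, so neither can be read alone. No supporting measurement bears on this result. Open, as far as these compounds go, are 3-bromophenyl and 4-chlorophenyl, which would separate those two changes, and an amine or a carboxylic acid on this ring.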